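From morpholin-4-yl to piperazin-1-yl on compound 2

This account rests on a few compounds, and the source may have more. Where it says the series, first, only, none or still open, it means among the compounds named here.

Within the data shown here, only two compounds have been measured so far in a functional assay on A20 cells (Mus musculus) for inhibition, with stated times of 1 h, 16 h and 24 h; on this read-out lower numbers stand for stronger inhibition and higher numbers for weaker inhibition. There, compound 1 (`N#CCNC(=O)[C@@H]1CC(F)(F)C[C@H]1C(=O)N1CCOCC1`) gives 925 nM. Compound 2 (`N#CC1(NC(=O)[C@@H]2C[C@@H](S(=O)(=O)c3ccccc3)C[C@H]2C(=O)N2CCOCC2)CC1`) gives 12 nM, the lower of the two numbers, and its gap to compound 1 lies beyond the usual scatter. The two structures differ in more than one place, so this gap cannot be assigned to any single group.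

The next compound to be tested is compound 3 (`N#CC1(NC(=O)[C@@H]2C[C@@H](S(=O)(=O)c3ccccc3)C[C@H]2C(=O)N2CCNCC2)CC1`). It keeps the rest of compound 2 and carries piperazin-1-yl in place of morpholin-4-yl on a carbonyl carbon. Both groups are six-membered non-aromatic rings with 2 hetero atoms. Among the measured compounds shown here, no measured pair shows how this assay responds to this exchange, so the expectation rests on compound 2 at 12 nM and on the structural change alone. The expected 1.2-fold lower number from compound 2 to compound 3 (0.08 log units; within the scatter) stays within the scatter, with no firm direction. For compound 3 the estimated value is 10 nM, with an expected range from 3 nM to 35 nM.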

Compound 3, half-maximal inhibitory concentration: 1340 nM
Compound 3: the middle estimate sits 130-fold (2.13 log units) below what was measured, and the stated range ends below it.
By their numbers in this assay, from the lowest: compound 2; then compounds 1 and 3 (each within the scatter of the next).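

In this assay, among these compounds, piperazin-1-yl in place of morpholin-4-yl on a carbonyl carbon gives a 110-fold higher number from compound 2 to compound 3 (2.05 log units; beyond the scatter), the first comparison that isolates this position, and it shows that the read-out is highly sensitive to the group placed there. The two groups match in having 6 heavy atoms and in being six-membered non-aromatic rings with 2 hetero atoms, and they differ in that a ring nitrogen stands where morpholin-4-yl has its oxygen, which moves the count from 0 hydrogen-bond donors to 1, so an exchange of one ring atom is enough for a step of this size. The data shown offer no measurement that would account for this loss.

The compounds shown leave open whether the step follows the hydrogen on the new ring nitrogen or the nitrogen itself, a question that 4-methylpiperazin-1-yl or piperidin-1-yl at the same carbonyl carbon could help to separate. They also leave open whether the exchange has a similar effect on another core, since this single pair shows it only with the rest of compound 2 held constant.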